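Demethylating a Methoxy Group: What the Read-out May Show

This account rests on a few compounds, and the source may have more. Where it says the series, first, only, none or still open, it means among the compounds named here.

Three compounds have been measured in a functional assay on SN12C cells (Homo sapiens) for cytotoxicity, read by sulforhodamine B assay, with a stated time of 48 h, tested at 0.01 uM; on this read-out higher numbers stand for a weaker effect at the one concentration tested and lower numbers for a stronger effect:

compound 1 `COc1cc(C)cc(-c2c(-c3ccnc(-c4ccc(N(C)C)cc4)c3)cnn2CC#N)c1` gives 75%
compound 2 `COc1cc(C)cc(-c2nn(CC#N)cc2-c2ccnc(-c3ccc(N(C)C)cc3)c2)c1` gives 90%
compound 3 `COc1cc(C)cc(-c2nn(CC#N)cc2-c2ccc(-c3cccc(C(C)=O)c3)nc2)c1` gives 88%

Among these three numbers, compound 2 carries the highest, which on this read-out means the weakest effect at the single concentration tested. The number of compound 3 lies close to it, within the usual scatter of repeated measurements, so the two cannot be told apart. The number of compound 1 lies further away, below that of compound 2 and beyond the scatter, so compound 1 shows the stronger effect of the pair.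

Compound 4 `Cc1cc(O)cc(-c2nn(CC#N)cc2-c2ccnc(-c3ccc(N(C)C)cc3)c2)c1` has not yet been measured. It differs from compound 2 in one place: hydrogen in place of methyl on an oxygen on an aromatic ring. Among the measured compounds shown here, no pair of measured compounds differs by this same change, so the size of its effect cannot be read from the measured set. With nothing to anchor it, the step is expected to stay within the scatter in this assay, in no particular direction. The expected step of a number 2 percentage points lower from compound 2 to compound 4 (within the scatter) is therefore small. Compound 4 is estimated to give 88%, with a range from 72% to 100%.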

Compound 4, a percentage reported as activity, at one concentration (the size of the read-out at that concentration, not a potency): 90%
Compound 4: the middle estimate sits 2 percentage points below what was measured; the measured number falls inside the stated range.
By their numbers in this assay, from the lowest: compound 1; then compounds 3, 2 and 4 (each within the scatter of the next).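

Among the compounds shown here, compound 4 gives the first direct reading of the change from methoxy to hydroxy on the 3-methoxy-5-methylphenyl group: in this assay the step reads no change at the digits printed from compound 2 to compound 4 (within the scatter) and so the methyl on that oxygen can be replaced by hydrogen without a visible shift in this read-out. The earlier compounds shown here could not show this, as no measured pair carried the same change, and the exchange now has a measured size at this position, though only on the core of compound 2 and only at the one concentration tested. No supporting measurement offers an explanation for this result.

Going by these compounds, a number from one concentration is not a potency, so it remains open whether compound 2 and compound 4 would stay together at other concentrations. On these data alone, it also remains open how the read-out would respond to a longer chain on that oxygen, such as ethyl, to an amine in place of the hydroxy group, or to the same methoxy to hydroxy change on the core of compound 1 or compound 3.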